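The source may hold more compounds than are shown below. What is called first, only, known or untested is meant among the compounds shown, and "the series" means these compounds.

Working notes on the series in a functional assay on MCF7 cells (Homo sapiens) for cytotoxicity, read by MTT assay, with a stated time of 4 days; on this read-out lower numbers stand for stronger inhibition and higher numbers for weaker inhibition. Compound 1 `Cc1ccc(S(=O)(=O)Oc2ccc3c(c2C)[C@H](Cn2cc(-c4ccccc4)nn2)[C@@]24CC(=O)[C@@](C)(CC[C@@H]32)C4)cc1` gives only a limit of the assay, > 20000 nM. Compound 2 `Cc1ccc(-c2cn(C[C@H]3c4c(ccc(OS(=O)(=O)c5ccc(C)cc5)c4C)[C@@H]4CC[C@@]5(C)C[C@]43CC5=O)nn2)cc1` likewise gives only a limit in this assay, > 20000 nM. Among the measured compounds shown here, the single measured step, a step that the two limits leave unreadable from compound 1 to compound 2, is a methyl in place of hydrogen on an aromatic carbon, and its size and direction cannot be read because both values are limits (the limit of > 20000 nM in this assay, at which 2 of the 2 values shown sit). Compound 2 therefore stands at the limit of this assay, with no numerical value to anchor it.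

Compound 3 `Cc1ccc(S(=O)(=O)Oc2ccc3c(c2C)[C@H](Cn2cc(-c4ccc(F)cc4)nn2)[C@@]24CC(=O)[C@@](C)(CC[C@@H]32)C4)cc1` differs from compound 2 by fluoro in place of methyl on an aromatic carbon of a six-membered aromatic ring of carbon only, para to a large group, so that 4-(4-methylphenyl)-1H-1,2,3-triazol-1-yl becomes 4-(4-fluorophenyl)-1H-1,2,3-triazol-1-yl. For the measured compounds named here, no measured step bears on this change; the only recorded step, a step that the two limits leave unreadable from compound 1 to compound 2, is itself unreadable, both compounds sitting at the limit (the limit of > 20000 nM in this assay, at which 2 of the 2 values shown sit). No step beyond the scatter is expected, and the estimated step is a step that the limit leaves unreadable from compound 2 to compound 3. Compound 3 is expected to give 25000 nM, within 8000 nM to 60000 nM, most likely again reported only as a limit.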

Compound 3, half-maximal inhibitory concentration: > 20000 nM
Compound 3 gave a limit, no number (the forecaster's own chance of this, stated with the estimate: 85%); the middle value is on the limit's open side.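

Compound 3 adds no readable step, and its comparisons with compound 1 and compound 2 cannot be read, because all three compounds sit at the same limit in this assay: the limit of > 20000 nM in this assay, at which 3 of the 3 values shown sit.

The compounds shown leave open whether hydrogen, methyl or fluoro at this place on the aromatic ring makes any difference to the read-out, and what numerical value any compound of this shared core would give.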